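A few compounds are considered here, and "the series" means these few. Any claim that something is new, unique, unknown or untested is made for them only; others in the source may bear on it.

Measured so far in a functional assay on MCF7 cells (Homo sapiens) for antiproliferative activity, read by MTT assay, with a stated time of 72 h; on this read-out lower numbers stand for stronger inhibition and higher numbers for weaker inhibition:
- compound 1 `CCn1c(C(=O)NCCC(=O)O)ccc1C(CC)(CC)c1ccc(C#CC(O)(CC)CC)c(C)c1`: > 50000 nM
- compound 2 `CCN(CC)CCNC(=O)c1cc(C(CC)(CC)c2ccc(C#CC(O)(CC)CC)c(C)c2)cn1CC`: 1800 nM

The value of compound 1 is a limit of the assay, not a number. Going by the values given here, compound 2 therefore holds the only actual number, so there is no measured step to calibrate against.

Compound 3 `CCn1cc(C(CC)(CC)c2ccc(C#CC(O)(CC)CC)c(C)c2)cc1C(=O)NCCCN(C)C` is not yet measured in this assay. It keeps the shared core of compound 2 and differs in the amide side chain: (dimethylamino)methyl in place of diethylamino on a saturated chain carbon, two bonds along the chain from an amide-type nitrogen. The swap is (dimethylamino)methyl in place of diethylamino, and no direction is favoured. The expected change is a 1.1-fold higher number from compound 2 to compound 3 (0.05 log units; within the scatter), within the usual scatter. For compound 3 the estimated value is 2000 nM, with an expected range of 700 nM to 6000 nM.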

Compound 3, half-maximal inhibitory concentration: 20200 nM
For compound 3 the middle estimate is 10-fold (1.00 log units) below the measured one, outside the stated range (above it).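

In this assay the amide side chain proves to be a sensitive place on the shared core: (dimethylamino)methyl in place of diethylamino gives an 11-fold higher number from compound 2 to compound 3 (1.05 log units; beyond the scatter). Going by these compounds alone, this is the first measured step, and it shows that a small change in the side chain, with the amine kept, can move the number well beyond the scatter. Nothing measured here accounts for the size of this step.

The step combines a change in chain length with a change on the amine, so a 2-(dimethylamino)ethyl or 3-(diethylamino)propyl side chain would be needed to separate the two. From the compounds shown here alone, how a cyclic amine such as piperidine would behave on this chain also stays open.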